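Cytotoxicity limits in the series: benzamido to isopropoxy

The source may hold more compounds than are shown below. What is called first, only, known or untested is meant among the compounds shown, and "the series" means these compounds.

Compound 1 `COc1ccc(C2=C(c3cc(OC)c(OC)c(OC)c3)C(=O)C(O)C2)cc1NC(=O)c1ccccc1` is measured in an ADME assay on ECV-304 cells (Homo sapiens) for cytotoxicity, read by MTT assay, with a stated time of 72 h (a higher number here means a weaker inhibitor, a lower number a stronger inhibitor), and compound 1 gives > 100 ug/mL as a limit of the assay, not a number. Compound 2 `COc1ccc(C2=C(c3cc(OC)c(OC)c(OC)c3)C(=O)CC2O)cc1` gives > 100 ug/mL as a limit too. Within the data shown here, the measured picture so far is the limit of > 100 ug/mL in this assay, at which 2 of the 2 values shown sit, and no numeric step exists between any two compounds.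

Compound 3 `COc1ccc(C2=C(c3cc(OC)c(OC)c(OC)c3)C(=O)C(O)C2)cc1OC(C)C` keeps the core of compound 1 and carries isopropoxy in place of benzamido on an aromatic carbon, ortho to a methoxy group. The counted change is isopropoxy in place of benzamido on an aromatic carbon and it is the only difference between the two structures.

Among the measured compounds shown here, with no measured step to lean on, the expectation in this assay is no step beyond the scatter, and any readable move would run toward a stronger inhibitor. Compound 1 stands at > 100 ug/mL as a limit, so a limit is also a likely report for compound 3. The estimated step is a number no higher from compound 1 to compound 3 (the limit leaves the size open) on these grounds. For compound 3 the estimated value is 100 ug/mL with an expected range from 30 ug/mL to 200 ug/mL in this estimate.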

Compound 3, half-maximal inhibitory concentration: > 100 ug/mL
Compound 3: only a limit was reported (the forecaster's own chance of this, stated with the estimate: 60%); the middle value lies on the limit itself.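

In this assay compound 3 gives > 100 ug/mL, a limit of the assay and not a number. Compound 1 also stands at a limit, so no step can be read between compound 1 and compound 3, and the series offers only this: the limit of > 100 ug/mL in this assay, at which 3 of the 3 values shown sit. The compounds shown leave open what size, if any, the change from benzamido to isopropoxy has in this assay.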